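Notes on a side-chain extension within one core series

The compounds below may be only part of what the source reports. "The series", "measured", "known", "first", "only" and "open" are said of these compounds alone.

Compound 1 `CC(C)=CCC/C(C)=C/COc1cc(=O)n(CCCO)c2c1CC(CC=C(C)C)C(C)(C)C2` and compound 3 `CC(C)=CCC/C(C)=C/COc1cc(=O)n(CCCO)c2c1CC(C/C=C(\C)CCC=C(C)C)C(C)(C)C2` share a core and differ in a single change, (3-methylbut-2-en-1-yl in place of hydrogen on a saturated chain carbon bound to a double-bonded chain carbon). In a functional assay on PANC-1 cells (Homo sapiens) for inhibition, read by MTT assay, with a stated time of 24 h, tested at 10 uM (a higher number here means more inhibition at the concentration tested (going by the name of the read-out), a lower number less inhibition), compound 1 gives 10.6% and compound 3 gives 15.8%, a step of a number 5.2 percentage points higher from compound 1 to compound 3 (within the scatter). Compound 2 `CC(C)=CCC1Cc2c(OCCCNS(=O)(=O)c3ccc(C(F)(F)F)cc3)cc(=O)n(CCCO)c2CC1(C)C` carries a different side chain; how its core differs from the core of compound 1 is not broken down here. In this assay compound 2 gives 29.6%, the highest of the three measured numbers, and its gaps to compound 3 and to compound 1 both lie beyond the scatter. Compound 4 `CC(C)=CCC/C(C)=C/CC1Cc2c(OCCCNS(=O)(=O)c3ccc(C(F)(F)F)cc3)cc(=O)n(CCCO)c2CC1(C)C`, not yet measured, arises from compound 2 by 3-methylbut-2-en-1-yl in place of hydrogen on a saturated chain carbon bound to a double-bonded chain carbon, the same change that turns compound 1 into compound 3, made at the same place. For the measured compounds named here, the only precedent, a number 5.2 percentage points higher from compound 1 to compound 3 (within the scatter), stayed within the scatter, so a step of a number 5.4 percentage points higher from compound 2 to compound 4 (within the scatter) in this assay is expected, resting on that earlier step. For compound 4 an inhibition of 35% is estimated, with a range from 24% to 46%.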

Compound 4, a percentage reported as inhibition, at one concentration (the size of the read-out at that concentration, not a potency): 26.4%
Compound 4: middle estimate off by 8.6 percentage points, on the high side; measured number inside the range.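

In this assay, replacing 3-methylbut-2-en-1-yl with 3,7-dimethylocta-2,6-dien-1-yl on the core of compound 2 gives a step of a number 3.2 percentage points lower from compound 2 to compound 4 (within the scatter), so on this second core the extension again stays within the scatter. Set beside the earlier step, the two do not separate: the same change on two cores in this assay, a number 5.2 percentage points higher (within the scatter) from compound 1 to compound 3 and a number 3.2 percentage points lower (within the scatter) from compound 2 to compound 4, 8.4 percentage points apart, within the scatter of two such steps This shows that the change carries from one core to the other without a step beyond the scatter in either case, but it does not show a true rise on one core and a true fall on the other, nor that the chain length is without effect in general, as only two pairs at a single concentration are available.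

Still open, from the compounds shown here alone, is whether an amine or a carboxylic acid in place of the 3,7-dimethylocta-2,6-dien-1-yl chain, or a longer chain at the same place, would give a step beyond the scatter. Also open, going by these compounds, is whether a nitrile in place of the trifluoromethyl group of compound 2 would alter the number.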